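The compounds below may be only part of what the source reports. "The series", "measured", "known", "first", "only" and "open" are said of these compounds alone.

Measured so far: compound 1 `O=C(CSc1nc2c(c(=O)n1-c1ccccc1)SCC2)Nc1ccc(-c2ccoc2)cn1` gives 1.5 nM in an assay on L cells for inhibition of Protein-serine O-palmitoleoyltransferase porcupine (Mus musculus), read by reporter gene assay, with a stated time of 24 h; a higher number here means that more compound is needed for the effect, a lower number that less compound is needed; compound 2 `COc1ccc(-n2c(SCC(=O)Nc3nc4ccc(Cl)cc4s3)nc3c(c2=O)SCC3)cc1` gives 35 nM; compound 3 `COc1ccc(-n2c(SCC(=O)Nc3nc4ccc(C(F)(F)F)cc4s3)nc3c(c2=O)SCC3)cc1` gives 100 nM.

For the measured compounds named here, compound 3 stands highest of the three, with compound 2 nearest and compound 1 furthest; the step of a 2.9-fold higher number from compound 2 to compound 3 (0.46 log units; beyond the scatter) is the only single change measured here. Compound 4 `O=C(CSc1nc2c(c(=O)n1-c1ccccc1)SCC2)Nc1nc2ccc(C(F)(F)F)cc2s1` differs from compound 3 by hydrogen in place of methoxy on an aromatic carbon. Going by the values given here, no measured step bears on this change: compound 1 carries phenyl but also a different amide partner, so its value shows only that both changes together give a much lower number. With nothing to guide it, compound 4 is expected to stay near compound 3, with no step beyond the scatter, a 1.4-fold lower number from compound 3 to compound 4 (0.15 log units; within the scatter). The estimate for compound 4 is 70 nM, within 25 nM to 250 nM.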

Compound 4, half-maximal effective concentration: 40 nM
Estimate against measurement, compound 4: 1.8-fold (0.24 log units) above, and the stated range covers the measured number.
By their numbers in this assay, from the lowest: compound 1; then compounds 2 and 4 (each within the scatter of the next); then compound 3.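

At the aromatic carbon para to a large group, the change from 4-methoxyphenyl to phenyl gives a 2.5-fold lower number from compound 3 to compound 4 (0.40 log units; beyond the scatter) in this assay. For the compounds shown here, this is the first single change measured at this position, and it shows that the methoxy is not needed here: the number falls without it. Nothing available explains why this step occurs.

The compounds shown leave open whether a fluoro, a hydroxyl or an amine at this position would give a lower or a higher number. They also leave open whether the step holds with the amide partner of compound 1.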